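The source may report more compounds than this note shows. Statements on the series, on what has been measured and on what is new or still open speak of the compounds shown alone.

Measured so far in a functional assay on DU-145 cells (Homo sapiens) for cytotoxicity, read by MTT assay; on this read-out lower numbers stand for stronger inhibition and higher numbers for weaker inhibition:

Compound 1, `CC(O)(CSc1ccccc1)c1nc(-c2ccc(F)c(Cl)c2)no1`, gives 5500 nM.
Compound 2, `CC(O)(CSc1ccc(Br)cc1)c1nc(-c2ccc(F)c(Cl)c2)no1`, gives 8800 nM.
Compound 3, `CC(O)(CSc1ccc(Br)cc1)c1nc(-c2ccc([N+](=O)[O-])c(C(F)(F)F)c2)no1`, gives 1600 nM.

Compound 3 stands lowest of the three; its nearest neighbour is compound 1, and compound 2 lies furthest from it. Compound 2 and compound 3 share the same arylsulfanyl part but differ in their cores; the difference between the two cores is not broken down here.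

Compound 4, `CC(O)(CSc1ccccc1)c1nc(-c2ccc([N+](=O)[O-])c(C(F)(F)F)c2)no1`, has not yet been measured in this assay. It carries the core of compound 3 with the change (hydrogen in place of bromo on an aromatic carbon). The same change, (hydrogen in place of bromo on an aromatic carbon), is already measured on the core of compound 1 and compound 2 as a 1.6-fold lower number from compound 2 to compound 1 (0.20 log units; within the scatter). The place of the change is the same in both pairs, so this is the same change. Resting on that measured step from compound 2 to compound 1, the expected step for compound 4 is a 1.6-fold lower number from compound 3 to compound 4 (0.20 log units; within the scatter), again a small one. Compound 4 is therefore estimated at 1000 nM, expected within 400 nM to 2500 nM.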

Compound 4, half-maximal inhibitory concentration: 3000 nM
The estimate for compound 4 lay 3.0-fold (0.48 log units) below the measured number; the measured number lies above the stated range.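

On the core of compound 3, hydrogen in place of bromo on an aromatic carbon gives a 1.9-fold higher number from compound 3 to compound 4 (0.27 log units; within the scatter) in this assay. Set beside the step measured on the core of compound 1 and compound 2, this step does not agree with it, so the earlier step could not be carried over to this core: the same change on two cores in this assay, a 1.6-fold lower number (0.20 log units; within the scatter) from compound 2 to compound 1 and a 1.9-fold higher number (0.27 log units; within the scatter) from compound 3 to compound 4, 3.0-fold (0.48 log units) apart, beyond the scatter of two such steps This shows that, for these two pairs, the 4-bromophenyl to phenyl swap cannot be read from one core and applied to the other; it does not show why the steps differ, and it gives no general rule for the series, as each step on its own lies within the scatter and only two cores are compared.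

The compounds shown leave open how a chloro group, a methoxy group or an amine in place of the bromo would read on these two cores. They also leave open whether a third core would follow the step seen on either of them.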